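A few compounds are considered here, and "the series" means these few. Any claim that something is new, unique, unknown or untested is made for them only; others in the source may bear on it.

- compound 1 `COc1cc(C(=O)c2ccc(OC)c(O)c2OC)cc(OC)c1O`: 818 nM
- compound 2 `COc1cc(C(=O)c2ccc3c(c2)oc(=O)n3S(C)(=O)=O)cc(OC)c1OC`: 3040 nM
- compound 3 `COc1ccc(C(=O)c2cc(OC)c(OC)c(OC)c2)c(O)c1O`: 144 nM

These values come from a functional assay on DU-145 cells (Homo sapiens) for cytotoxicity, read by sulforhodamine B assay, with a stated time of 48 h; on this read-out higher numbers stand for weaker inhibition of growth and lower numbers for stronger inhibition of growth. Compound 3 gives 144 nM, the lowest of the three numbers, and its gaps to compound 1 and compound 2 both lie beyond the scatter.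

Compound 4 `COc1ccc(C(=O)c2cc(OC)c(OC)c(OC)c2)c(OC)c1O` is compound 3 with one small change: methyl in place of hydrogen on an oxygen on an aromatic ring. A hydroxy becomes a methoxy, with methyl in place of hydrogen on an oxygen on an aromatic ring. Going by the values given here, no measured pair shows this change alone, so its effect has to be judged loosely. The part of compound 4 that changes also occurs in compound 1 , which gives 818 nM and is weaker than compound 3 . That compound also differs elsewhere, so it is only a rough guide. Weaker growth inhibition is therefore expected, by a moderate amount that probably exceeds the scatter. The expected step runs a 2.9-fold higher number from compound 3 to compound 4 (0.46 log units; beyond the scatter). For compound 4 the estimated value is 420 nM, with an expected range from 120 nM to 1500 nM.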

Compound 4, concentration for 50% growth inhibition: 20.9 nM
Compound 4: middle estimate off by 20-fold (1.30 log units), on the high side; the measured number lies below the stated range.
By their numbers in this assay, from the lowest: compound 4; then compound 3; then compound 1; then compound 2.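

In this assay, putting a methyl on this oxygen gives a 6.9-fold lower number from compound 3 to compound 4 (0.84 log units; beyond the scatter), so a free hydroxy at this place is not needed for growth inhibition in these cells, and the methoxy does better here. The same hydroxy-to-methoxy change at a different oxygen of the shared core gives a 39-fold lower number from compound 1 to compound 4 (1.59 log units; beyond the scatter), so both single changes that lead to compound 4 point the same way, with the larger step at that other oxygen. Nothing available here explains why the number falls in either case.

Whether the trend stops at methyl stays open, since a longer chain on this oxygen, such as ethoxy, has no value among these compounds. An amine in place of the hydroxy is equally untested by the values shown here.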